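This account rests on a few compounds, and the source may have more. Where it says the series, first, only, none or still open, it means among the compounds named here.

Compound 1 `C=CC(=O)Nc1cc(Nc2ncc(Cl)c(Nc3ccccc3S(=O)(=O)C(C)C)n2)c(OC)cc1N1CCN(C)CC1` is a covalent inhibitor tested in a functional assay on NCI-H1975 cells (Homo sapiens) for inhibition, read by CellTiter-Glo, with a stated time of 72 h; on this read-out lower numbers stand for stronger inhibition of growth and higher numbers for weaker inhibition of growth. In that assay compound 1 gives 43 nM, the lowest of the two numbers in hand. Its companion, compound 2 `C=CC(=O)Nc1cc(Nc2ncc(Cl)c(Nc3ccccc3S(=O)(=O)C(C)C)n2)c(OC)cc1N1CCCCC1`, gives 240 nM and differs only by a 5.6-fold higher number from compound 1 to compound 2 (0.75 log units; beyond the scatter). The untested compound 3 `C=CC(=O)Nc1cc(Nc2ncc(Cl)c(NCc3cccs3)n2)c(OC)cc1N1CCN(C)CC1` changes a different place: (thiophen-2-yl)methyl in place of 2-(isopropylsulfonyl)phenyl on a nitrogen on an aromatic ring. Among the compounds with values here, no measured step touches that position, so the step to compound 2 gives no direct guide, and a larger piece leaves than enters. A weakening is therefore expected, with compound 3 estimated at 600 nM (range 120 nM to 3000 nM), a step of a 14-fold higher number from compound 1 to compound 3 (1.14 log units; beyond the scatter).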

Compound 3, concentration for 50% growth inhibition: 220 nM
The estimate for compound 3 lay 2.7-fold (0.44 log units) above the measured number; the range from low to high includes it.
By their numbers in this assay, from the lowest: compound 1; then compounds 3 and 2 (each within the scatter of the next).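

In this assay, putting (thiophen-2-yl)methyl in place of 2-(isopropylsulfonyl)phenyl on this nitrogen gives a 5.1-fold higher number from compound 1 to compound 3 (0.71 log units; beyond the scatter) and shows that this position also affects growth inhibition. Even so, compound 3 gives 220 nM with no sulfonyl group, so a sulfonyl group is not required for activity at this level. Nothing measured here explains the size of the step. The compounds shown leave open whether the sulfonyl group, the ring or the methylene link accounts for the change. A benzyl group or a 2-(methylsulfonyl)phenyl group on this nitrogen would help separate these.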